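The source may report more compounds than this note shows. Statements on the series, on what has been measured and on what is new or still open speak of the compounds shown alone.

Measured so far in a functional assay on PC-12 cells (Rattus norvegicus) for cytotoxicity, read by MTT assay, with stated times of 3 h and 2 h, tested at 10 uM; a higher number here means a stronger effect of the compound at the concentration tested, a lower number a weaker effect: compound 1 `Cc1cc(=O)oc2cc(OCCCn3cc(CNC(=O)CCCCC4CCSS4)nn3)ccc12` gives 69.4%; compound 2 `CC(=O)c1cc2ccc(OCCCn3cc(CNC(=O)CCCCC4CCSS4)nn3)cc2oc1=O` gives 38%; compound 3 `O=C(CCCCC1CCSS1)NCc1cn(CCCOc2ccc3cc(-c4ccccc4)c(=O)oc3c2)nn1` gives 29.1%.

Compound 2 stands second highest of the three numbers. Its nearest neighbour is compound 3, which lies within the scatter of it; compound 1 lies higher, beyond the scatter.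

Compound 4 `COc1ccc(-c2cc3ccc(OCCCn4cc(CNC(=O)CCCCC5CCSS5)nn4)cc3oc2=O)cc1` differs from compound 2 as follows: 4-methoxyphenyl in place of acetyl on an aromatic carbon. Within the data shown here, the only measured step that bears on this is a number 8.9 percentage points lower from compound 2 to compound 3 (within the scatter), where an aromatic ring also took the place of the acetyl at the same position and the read-out shifted only within the scatter. A step of comparable size, if any, is therefore expected here, with no shift beyond the scatter.

The estimate for compound 4 in this assay is 31%, with a range of 18% to 44%, which would mean an expected step of a number 7 percentage points lower from compound 2 to compound 4 (within the scatter).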

Compound 4, a percentage reported as activity, at one concentration (the size of the read-out at that concentration, not a potency): 57.6%
Compound 4: the middle estimate sits 26.6 percentage points below what was measured; the measured number lies above the stated range.
By their numbers in this assay, from the lowest: compounds 3 and 2 (each within the scatter of the next); then compound 4; then compound 1.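

Replacing acetyl with 4-methoxyphenyl on this aromatic carbon gives a number 19.6 percentage points higher from compound 2 to compound 4 (beyond the scatter), whereas phenyl in the same place gave a number 8.9 percentage points lower from compound 2 to compound 3 (within the scatter). Methoxy in place of hydrogen on that phenyl gives a number 28.5 percentage points higher from compound 3 to compound 4 (beyond the scatter). In this assay, the read-out at this position therefore depends on what the aromatic ring carries, not merely on an aromatic ring being present. On these data alone, whether a hydroxy or dimethylamino group in place of the methoxy would shift the read-out as far remains open. Nothing available accounts for the shift produced by the methoxy group.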